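Swapping the Ring on the Thiocarbonyl Carbon

A few compounds are considered here, and "the series" means these few. Any claim that something is new, unique, unknown or untested is made for them only; others in the source may bear on it.

Of the compounds shown here, three have been measured in a functional assay on MCF7 cells (Homo sapiens) for cytotoxicity, read by MTT assay, with a stated time of 72 h, tested at 30 uM; on this read-out higher numbers stand for more inhibition of growth at the one concentration tested and lower numbers for less inhibition of growth. Compound 1 `Cc1ccnc(/C(N)=N/NC(=S)N2CCSCC2)c1` gives 74.2%, compound 2 `N/C(=N\NC(=S)N1CCSCC1)c1ccccn1` gives 72.6%, and compound 3 `N/C(=N\NC(=S)N1CCN(c2ccccn2)CC1)c1ccccn1` gives 65.3%. Going by the values given here, compound 2 thus stands second highest of the three; its nearest neighbour is compound 1, and the only one-place step, a number 1.6 percentage points lower from compound 1 to compound 2 (within the scatter), lies within the scatter. Compound 3 is not joined to compound 2 by a single listed step; its value is simply somewhat lower, still within the scatter.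

Compound 4 `N/C(=N\NC(=S)N1CCCC1)c1ccccn1` is the next to be tested. It differs from compound 2 by pyrrolidin-1-yl in place of thiomorpholin-4-yl on a thiocarbonyl carbon. Among the compounds with values here, no measured step touches the ring on the thiocarbonyl carbon directly; the one step on record concerns a methyl on an aromatic carbon and was flat. The values of compounds 2 and 3, which carry different rings at that position, also sit within the scatter of each other. The account therefore expects no step beyond the scatter, a number 2.6 percentage points lower from compound 2 to compound 4 (within the scatter). For compound 4 the estimated value is 70%, within the range 55% to 82%.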

Compound 4, percent growth inhibition at one concentration: 54.6%
Compound 4: middle estimate off by 15.4 percentage points, on the high side; the measured number lies below the stated range.
By their numbers in this assay, from the lowest: compound 4; then compounds 3, 2 and 1 (each within the scatter of the next).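

The ring on the thiocarbonyl carbon turns out to matter in this assay: pyrrolidin-1-yl in place of thiomorpholin-4-yl gives a number 18 percentage points lower from compound 2 to compound 4 (beyond the scatter) and is the first step shown to go beyond the scatter, whereas the methyl change on the aromatic carbon stayed within it. This one change both removes the ring sulfur and replaces the six-membered ring with a five-membered one, so the step alone cannot separate the two. No evidence is at hand that would account for the drop.

On these data alone, it remains open whether piperidin-1-yl, or morpholin-4-yl with oxygen in place of the sulfur, would stay with compound 2 or fall towards compound 4. An open-chain dimethylamino group on the same carbon would show whether a ring is needed there at all.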